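Naphthyl series: bromo analogue of compound 3 ahead of measurement

The source may hold more compounds than are shown below. What is called first, only, known or untested is meant among the compounds shown, and "the series" means these compounds.

Measured so far:
compound 1, `CC(=O)N1N=C(c2ccco2)CC1c1ccccc1[N+](=O)[O-]`, gives 19000 nM in a functional assay on PC-3 cells (Homo sapiens) for cytotoxicity, read by sulforhodamine B assay, with a stated time of 48 h; on this read-out higher numbers stand for weaker inhibition and lower numbers for stronger inhibition
compound 2, `CC(=O)N1N=C(c2ccco2)CC1c1cccc(O)c1`, gives 16500 nM in this assay
compound 3, `CC(=O)N1N=C(c2cccc3ccccc23)CC1c1ccccc1`, gives 8460 nM in this assay

Compound 3 holds the lowest of the three numbers. Its gap to compound 2 lies within the usual scatter, so the two cannot be told apart on this read-out; its gap to compound 1 lies just beyond the scatter. Within the data shown here, all three share the same acetylated core and differ in the aryl groups at its two ends, and no pair among them differs in one place only, so none of these gaps can be read as the effect of a single change.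

Compound 4, `CC(=O)N1N=C(c2cccc3ccccc23)CC1c1cccc(Br)c1`, is the next one to go into this assay. It differs from compound 3 by bromo in place of hydrogen on an aromatic carbon, phenyl to 3-bromophenyl. Among the measured compounds shown here, nothing among the measured compounds shows what such a substitution does here, so the expectation rests on compound 3 alone, with 8460 nM as the anchor. The step from compound 3 to compound 4 is expected to be small, a 1.3-fold lower number from compound 3 to compound 4 (0.11 log units; within the scatter), and may well fall within the scatter. For compound 4 the estimate is 6500 nM, with a range from 2500 nM to 20000 nM.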

Compound 4, half-maximal inhibitory concentration: 12000 nM
Compound 4: middle estimate off by 1.8-fold (0.27 log units), on the low side, within the range that was stated.
By their numbers in this assay, from the lowest: compounds 3, 4, 2 and 1 (each within the scatter of the next, the first and the last beyond it).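

Among these compounds, compound 3 and compound 4 form the first pair that differs in one place only, so a single substitution can now be read directly: in this assay the step is a 1.4-fold higher number from compound 3 to compound 4 (0.15 log units; within the scatter) and stays within the scatter. Compound 3 and compound 4 therefore cannot be told apart on this read-out, which means that bromo on this aromatic carbon, meta to a large group, leaves no readable mark on the number, and that this position accepts one bromine atom without a step beyond the scatter. No measured property in hand bears on this result, and nothing can be said about what lies behind it.

From the compounds shown here alone, what other groups do at this same place stays open, for example an amine, a carboxylic acid or a longer chain such as propyl, any of which could give a step beyond the scatter where bromo does not. Also open, going by these compounds, is whether bromo reads the same way on a different carbon of this ring, or when paired with the other aryl end carried by compound 1 and compound 2.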